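Swapping the benzyl of compound 1 for a methoxyphenyl

The source may report more compounds than this note shows. Statements on the series, on what has been measured and on what is new or still open speak of the compounds shown alone.

Measured so far:
compound 1, `C=C(Br)C(=O)Nc1cccc(-c2cn3nc(Cc4ccccc4)sc3n2)c1`: 4500 nM
compound 2, `Nc1cccc(-c2cn3nc(Cc4ccccc4)sc3n2)c1`: 24000 nM
compound 3, `C=C(Br)C(=O)Nc1cccc(-c2cn3c(-c4ccc(Cl)cc4)csc3n2)c1`: 3000 nM

These numbers come from a functional assay on HeLa cells (Homo sapiens) for inhibition, read by cell counting, with a stated time of 4 days; on this read-out lower numbers stand for stronger inhibition and higher numbers for weaker inhibition. Among the three values, compound 1 stands second highest. Its nearest neighbour is compound 3, whose value is within the scatter of that of compound 1; the two differ in more than one place, so only the two values themselves can be compared. Within the data shown here, the furthest is compound 2, reached by the only single-point step: a 5.3-fold higher number from compound 1 to compound 2 (0.73 log units; beyond the scatter). That step concerns the group on the ring nitrogen, which compound 4 keeps unchanged.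

Compound 4, `C=C(Br)C(=O)Nc1cccc(-c2cn3nc(-c4ccc(OC)cc4)sc3n2)c1`, differs from compound 1 as follows: 4-methoxyphenyl in place of benzyl on an aromatic carbon. Among the measured compounds shown here, no measured step touches this position, so nothing on record tells how this change moves the read-out. The values of compound 1 and compound 3 suggest that varying the aryl portion of the core leaves the number within scatter. The expected step is therefore a 1.1-fold lower number from compound 1 to compound 4 (0.05 log units; within the scatter), essentially none beyond the scatter. Compound 4 is estimated at 4000 nM, in the range 1500 nM to 12000 nM.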

Compound 4, half-maximal inhibitory concentration: 2300 nM
The estimate for compound 4 lay 1.7-fold (0.24 log units) above the measured number; measured number inside the range.
By their numbers in this assay, from the lowest: compounds 4, 3 and 1 (each within the scatter of the next); then compound 2.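

Among these compounds, this is the first reading at this position of the shared core. In this assay, the swap gives a 2.0-fold lower number from compound 1 to compound 4 (0.29 log units; within the scatter), so benzyl and 4-methoxyphenyl cannot be told apart here, even though the entering group brings an oxygen and a hydrogen-bond acceptor that benzyl lacks. Nothing on record explains this result.

This one swap changes both the group's link to the core and the substituent on its ring. A plain phenyl would be needed to separate the two changes. From the compounds shown here alone, it also remains open whether the number would hold with a group of a different kind at this carbon, such as an amine, a carboxylic acid or a longer alkyl chain.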